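Shortening the aromatic-carbon substituent in a purine-like series

A few compounds are considered here, and "the series" means these few. Any claim that something is new, unique, unknown or untested is made for them only; others in the source may bear on it.

Measured so far:
compound 1, `Nc1nc(SCc2ccccc2)nc2c1nc(O)n2Cc1ccccc1`, 0.1 uM
compound 2, `CCCCCOc1nc(N)c2nc(O)n(Cc3ccccc3)c2n1`, 0.01 uM

Both measured compounds were tested in a functional assay (spleen, spleen) for activation, with Mus musculus as the target; on this read-out higher numbers stand for an effect only at larger amounts of compound and lower numbers for an effect already at smaller amounts. Compound 2 stands at the lowest number of the two, with compound 1 the nearest neighbour, a gap that is beyond the usual scatter. Within the data shown here, the one step on record, a 10-fold lower number from compound 1 to compound 2 (1.00 log units; beyond the scatter), is the only comparison available, and it involves the replacement of one substituent on the same aromatic carbon by another.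

Compound 3, `CSc1nc(N)c2nc(O)n(Cc3ccccc3)c2n1`, has not yet been measured. It differs from compound 2 as follows: methylsulfanyl in place of pentyloxy on an aromatic carbon. The recorded step concerns a different pair of groups at that carbon, so it bears on the new change only indirectly: it shows that the identity of the substituent on this aromatic carbon moves the read-out by a modest amount. With the pentyloxy group of compound 2 gone, the number for compound 3 is expected to rise, by an amount of a 50-fold higher number from compound 2 to compound 3 (1.70 log units; beyond the scatter), with wide uncertainty. Compound 3 is therefore estimated at 0.5 uM, within a range from 0.05 uM to 5 uM.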

Compound 3, minimum effective concentration: 0.1 uM
Beside the measured number, compound 3's estimate is 5.0-fold (0.70 log units) above it, and the stated range covers the measured number.
By their numbers in this assay, from the lowest: compound 2; then compounds 1 and 3 (each within the scatter of the next).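

In this assay, the change to methylsulfanyl on this aromatic carbon gives a 10-fold higher number from compound 2 to compound 3 (1.00 log units; beyond the scatter), so the low number of the pentyloxy compound is not kept by a small sulfur-linked group. Among these compounds, the other new comparison, no change at the digits printed from compound 1 to compound 3 (within the scatter), shows for the first time that, with the sulfur link held fixed, the phenyl on the saturated chain carbon can go without a readable effect on this read-out, so the earlier gap between the benzylsulfanyl and pentyloxy compounds does not rest on that phenyl. No supporting measurement accompanies these results, and nothing shown explains them.

The step from pentyloxy to methylsulfanyl alters the linking atom and the chain together, so these compounds cannot say which of the two matters; a methoxy or a pentylsulfanyl group on this carbon would separate them. On these data alone, it also remains open whether a butylamino group, with nitrogen as the link, or a chain longer than pentyloxy would fit the same trend on this read-out.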